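The source may hold more compounds than are shown below. What is called first, only, known or untested is meant among the compounds shown, and "the series" means these compounds.

Working notes on the series. Compound 1 `Cc1ccc(-c2cn(C/C=C3\OC(=O)C(OCc4ccccc4)=C3OCc3ccccc3)nn2)cc1` is the starting point for the step at hand. In a functional assay on HepG2 cells (Homo sapiens) for antiproliferative activity, read by MTT assay, with a stated time of 72 h (a higher number here means a weaker inhibitor, a lower number a stronger inhibitor), compound 1 gives only a limit, > 100000 nM, and not a number. Compound 2 `CCCCCc1ccc(-c2cn(C[C@H](O)[C@H]3OC(=O)C(OCc4ccccc4)=C3OCc3ccccc3)nn2)cc1` and compound 3 `CCCCCCCCCCc1cn(C[C@H](O)[C@H]2OC(=O)C(OCc3ccccc3)=C2OCc2ccccc2)nn1` carry a different core; in this assay compound 2 gives 7460 nM and compound 3 gives 12200 nM. Among the compounds with values here, the single measured step, a 1.6-fold higher number from compound 2 to compound 3 (0.21 log units; within the scatter), is an exchange of one large group for another and leaves the read-out essentially unchanged. Compound 4 `COc1ccccc1-c1cn(C/C=C2\OC(=O)C(OCc3ccccc3)=C2OCc2ccccc2)nn1` differs from compound 1 by 2-methoxyphenyl in place of 4-methylphenyl on an aromatic carbon. The step from compound 2 to compound 3 bears on this change only loosely, since it sits on another core and swaps other groups, but it is the one indication that such an exchange moves the read-out little. Compound 1 sits at the limit of > 100000 nM in this assay, at which 1 of the 3 values shown sits, so the numbers give no pointer toward a stronger inhibitor, and the step of a number no higher from compound 1 to compound 4 (the limit leaves the size open) is expected to stay within the scatter. Compound 4 is therefore expected near 100000 nM, in a range of 30000 nM to 300000 nM, most likely again reported only as a limit.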

Compound 4, half-maximal inhibitory concentration: > 100000 nM
Compound 4: no number, only a limit; the forecaster's own chance of this, stated with the estimate: 70%; the middle value lies on the limit itself.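

Compound 1 and compound 4 each give only a limit in this assay, so no step between them can be read: the limit of > 100000 nM in this assay, at which 2 of the 4 values shown sit.

The compounds shown leave open whether 2-methoxyphenyl in place of 4-methylphenyl moves the read-out at all on the core of compound 1.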